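Swapping a methoxyphenyl for a pyrimidine on the thioether arm

The source may hold more compounds than are shown below. What is called first, only, known or untested is meant among the compounds shown, and "the series" means these compounds.

Measured so far:
- compound 1, `COc1cccc(C(C)Sc2nc3c(cnn3C)c(=O)n2-c2ccccc2)c1`, 174 nM
- compound 2, `CC(Sc1nc2nn(C3COC3)cc2c(=O)n1-c1ccccc1)c1ccccn1`, 480 nM

Compound 1 stands as the lowest of the two numbers in an assay on isolated protein for inhibition of Retinaldehyde dehydrogenase 3 (Homo sapiens); a lower number here means a stronger inhibitor, a higher number a weaker inhibitor; the nearest is compound 2, whose number in this assay lies beyond the scatter of compound 1. For the measured compounds named here, the two differ in more than one place, so their values show only that compound 2 is the weaker of the pair, and no single step can be read from them.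

Compound 3, `CC(Sc1nc2c(cnn2C)c(=O)n1-c1ccccc1)c1cncnc1`, is not yet measured. It departs from compound 1 by one change: pyrimidin-5-yl in place of 3-methoxyphenyl on a saturated chain carbon bound to a saturated chain carbon and a sulfur. Going by the values given here, no measured pair shows this change. Compound 3 is expected to fall off from compound 1 by a 2.9-fold higher number from compound 1 to compound 3 (0.46 log units; beyond the scatter), a moderate loss, since compound 1 gives 174 nM and nothing measured here points upward. Compound 3 is estimated at 500 nM, between 150 nM and 1600 nM.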

Compound 3, half-maximal inhibitory concentration: 100 nM
For compound 3 the middle estimate is 5.0-fold (0.70 log units) above the measured one, outside the stated range (below it).
By their numbers in this assay, from the lowest: compounds 3 and 1 (each within the scatter of the next); then compound 2.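

For the compounds shown here, the single step at this position shows that, on a saturated chain carbon bound to a saturated chain carbon and a sulfur, pyrimidin-5-yl can stand in place of 3-methoxyphenyl in this assay with the two compounds reading alike: a 1.7-fold lower number from compound 1 to compound 3 (0.24 log units; within the scatter). The earlier pair differed in more than one place and could show nothing of the kind; here, a six-membered aromatic ring with 2 hetero atoms and 6 heavy atoms matches a carbon-only ring carrying methoxy with 8 heavy atoms. No available information accounts for this match.

Going by these compounds, what a saturated ring such as piperidine or a plain methyl would give on this carbon remains open. So does the effect of an amine or a carboxylic acid on the pyrimidine ring.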